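The source may hold more compounds than are shown below. What is called first, only, known or untested is meant among the compounds shown, and "the series" means these compounds.

Compound 1 `CNC(=O)c1cnc(N2CCN(C3CCN(Cc4ccc(Cl)cc4)CC3)[C@@H](C)C2)c(Cl)c1` gives 32 nM in a functional assay for antagonist activity at C-X-C chemokine receptor type 3 (Homo sapiens); a higher number here means a weaker inhibitor, a lower number a stronger inhibitor.
Compound 2 `CNC(=O)c1cnc(N2CCN(C3CCN(Cc4ccc(Cl)cc4Cl)CC3)[C@@H](C)C2)c(Cl)c1` gives 17 nM in this assay.
Compound 3 `CNC(=O)c1cnc(N2CCN(C3CCN(C(=O)c4ccc(Cl)cc4)CC3)[C@@H](C)C2)c(Cl)c1` gives 210 nM in this assay.

Among these three, compound 1 is not separated from compound 2 beyond the scatter (a 1.9-fold lower number from compound 1 to compound 2 (0.27 log units; within the scatter)), while compound 3 stands clearly apart (a 6.6-fold higher number from compound 1 to compound 3 (0.82 log units; beyond the scatter)), and the step of a 12-fold higher number from compound 2 to compound 3 (1.09 log units; beyond the scatter) is the widest of all. Compound 4 `CC(=O)Nc1cnc(N2CCN(C3CCN(Cc4ccc(Cl)cc4)CC3)[C@@H](C)C2)c(Cl)c1` differs from compound 1 in one change: acetamido in place of methylcarbamoyl on an aromatic carbon. Going by the values given here, none of the measured steps alters this part of the molecule; all of them change the group on the amine nitrogen in the ring, so they give no direct guide here. The step expected from compound 1 to compound 4 is therefore small and uncertain, set as a 2.5-fold higher number from compound 1 to compound 4 (0.40 log units; beyond the scatter), leaning towards a weaker inhibitor. For compound 4 the estimate in this assay is 80 nM, with a range from 20 nM to 400 nM.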

Compound 4, half-maximal inhibitory concentration: 8 nM
Estimate against measurement, compound 4: 10-fold (1.00 log units) above; the whole stated range lies above it.
By their numbers in this assay, from the lowest: compound 4; then compounds 2 and 1 (each within the scatter of the next); then compound 3.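

Joining the same atoms the other way round, as acetamido in place of methylcarbamoyl, gives a 4.0-fold lower number from compound 1 to compound 4 (0.60 log units; beyond the scatter) in this assay. Going by these compounds alone, all earlier steps changed the group on the amine nitrogen in the ring, so this is the first sign that the group on the aromatic carbon also matters, and that the direction of the amide link counts even with matching atom counts. No measurement shown here accounts for this step. Open, from the compounds shown here alone, is whether propionamido, with its longer chain, or a carboxylic acid at this position would give a stronger or weaker inhibitor. Also open, going by these compounds, is whether acetamido gives a similar step alongside 2,4-dichlorobenzyl.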